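Two ring-fused enones swap a bromophenyl for a methoxyphenyl

This account rests on a few compounds, and the source may have more. Where it says the series, first, only, none or still open, it means among the compounds named here.

Compound 1, `COc1cccc(/C=C2\CCC/C(=C\c3ccc(Br)cc3)C2=O)c1OC` — in a functional assay on A549 cells (Homo sapiens) for cytotoxicity, read by MTT assay, with a stated time of 72 h (on this read-out lower numbers stand for stronger inhibition and higher numbers for weaker inhibition), compound 1 gives > 20000 nM, a limit of the assay rather than a number.
Compound 2, `COc1ccccc1/C=C1\CCC/C(=C\c2cccc(OC)c2OC)C1=O` — in this assay compound 2 gives > 20000 nM, also a limit of the assay.
Compound 3, `COc1ccc(/C=C2\CCC/C(=C\c3ccc(Br)cc3)C2=O)cc1OC` — in this assay compound 3 gives 16000 nM.

Compound 1 and compound 2 differ in one place: 2-methoxyphenyl in place of 4-bromophenyl on a double-bonded chain carbon bound to a double-bonded ring carbon. Both values sit at the limit, so the step that the two limits leave unreadable from compound 1 to compound 2 cannot be read; this follows from the limit of > 20000 nM in this assay, at which 2 of the 3 values shown sit. Compound 3 is built from the same atoms as compound 1, joined differently; the difference between the two cores is not broken down here. Compound 3 is the only one of the three with a measured number.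

Compound 4, `COc1ccccc1/C=C1\CCC/C(=C\c2ccc(OC)c(OC)c2)C1=O`, has not been measured. It relates to compound 3 exactly as compound 2 relates to compound 1: 2-methoxyphenyl in place of 4-bromophenyl on a double-bonded chain carbon bound to a double-bonded ring carbon. The place is the same in both pairs, so this is the same change. As far as these compounds go, what that change does to the read-out is unknown from the measured pair, and compound 3 itself sits close to the limit. Compound 4 is therefore expected to give 25000 nM in this assay, most likely between 8000 nM and 80000 nM. This estimate means a step of a 1.6-fold higher number from compound 3 to compound 4 (0.19 log units; within the scatter). The expectation rests on compound 3 with 16000 nM and on the unreadable step that the two limits leave unreadable from compound 1 to compound 2, which leaves no measured direction for the change. For compound 4 an outcome reported only as a limit of the assay is quite possible.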

Compound 4, half-maximal inhibitory concentration: > 20000 nM
Compound 4: only a limit was reported; the forecaster's own chance of this, stated with the estimate: 55%; the middle value does not contradict the limit.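

In this assay, placing 2-methoxyphenyl in place of 4-bromophenyl on a double-bonded chain carbon bound to a double-bonded ring carbon gives an at least 1.2-fold higher number from compound 3 to compound 4 (0.09 log units; that floor lies within the scatter). Compound 4 gives > 20000 nM, which is a limit of the assay and not a number, so this step shows only a floor: the true size could be small or large, and the floor alone does not establish a real loss of activity. The step from compound 1 to compound 2 cannot be read, so the same change cannot be compared between the two cores, and nothing here shows that it carries over with the same size or even the same direction, because nearly all the values rest on one limit: the limit of > 20000 nM in this assay, at which 3 of the 4 values shown sit.

Among these compounds, compound 3 remains the only compound with a measured number, so it is open whether any change to these structures could bring the value clearly lower. Also open, as far as these compounds go, is how an amine or a carboxylic acid in place of 4-bromophenyl would read in this assay, and whether such a step would be readable on both cores.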